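The source may report more compounds than this note shows. Statements on the series, on what has been measured and on what is new or still open speak of the compounds shown alone.

Of the compounds shown here, three have been measured in an ADME assay on HEp-2 cells (Homo sapiens) for cytotoxicity; a higher number here means that more compound is tolerated, a lower number that less compound is tolerated. In this assay compound 1 `CC(C)CCn1c(CN2C(=O)C(=O)c3ccccc32)nc2ccccc21` gives 69800 nM. Compound 2 `O=C1N(Cc2nc3ccccc3n2CCCCF)c2ccccc2S(=O)(=O)N1C1CC1` gives 111000 nM, and compound 3 `CN1C(=O)N(Cc2nc3ccccc3n2CCCCF)c2ccccc2S1(=O)=O` gives 87700 nM. Of these three numbers, compound 3 stands second highest, yet it lies within the scatter of both of its neighbours, so the three values cannot be told apart with confidence. Among the measured compounds shown here, the only single-site step among the measured compounds is a 1.3-fold lower number from compound 2 to compound 3 (0.10 log units; within the scatter), and it stays within the scatter.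

Compound 4 `CN1C(=O)N(Cc2nc3ccccc3n2CCCCO)c2ccccc2S1(=O)=O` differs from compound 3 at a different place: hydroxy in place of fluoro on a saturated chain carbon, four bonds along the chain from an aromatic nitrogen. For the measured compounds named here, no measured step touches this exchange of fluoro for hydroxy, so the data give no direction for it. Going by the values given here, the one known step, which concerns a group on an amide-type nitrogen in a ring rather than the chain, did not reach beyond the scatter, and all three measured values sit close together. Because the known step of a 1.3-fold lower number from compound 2 to compound 3 (0.10 log units; within the scatter) shows so little movement, the expectation for compound 4 is a step of no change at the digits printed from compound 3 to compound 4 (within the scatter), that is, nothing beyond the scatter. Compound 4 is therefore estimated at 87700 nM, with a range from 40000 nM to 190000 nM.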

Compound 4, half-maximal cytotoxic concentration: 219000 nM
The estimate for compound 4 lay 2.5-fold (0.40 log units) below the measured number; the whole stated range lies below it.
By their numbers in this assay, from the lowest: compounds 1, 3, 2 and 4 (each within the scatter of the next, the first and the last beyond it).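

The exchange of fluoro for hydroxy on a saturated chain carbon, four bonds along the chain from an aromatic nitrogen, gives a 2.5-fold higher number from compound 3 to compound 4 (0.40 log units; beyond the scatter) in this assay, the first single-site step shown that moves beyond the scatter. This position at the chain end is therefore sensitive to a change of one heavy atom, and more compound is tolerated with hydroxy there, whereas methyl in place of cyclopropyl on the amide-type nitrogen in a ring gave only a 1.3-fold lower number from compound 2 to compound 3 (0.10 log units; within the scatter). The hydroxy brings a hydrogen-bond donor and acceptor that the fluoro lacks, but no measurement shown here accounts for the step.

As far as these compounds go, whether other groups at the chain end, such as an amine or a carboxylic acid, would move the number in the same direction remains open, as does the role of chain length, for example in a longer chain ending in hydroxy. From the compounds shown here alone, it is also open whether the same exchange of fluoro for hydroxy would give a similar step with the cyclopropyl group of compound 2 in place.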